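This account rests on a few compounds, and the source may have more. Where it says the series, first, only, none or still open, it means among the compounds named here.

Measured so far:

Compound 1, `CC/N=C(/NC#N)NCCCn1nc(-c2ccccc2)ccc1=O`: 88.5 mg/kg
Compound 2, `CN(C)/C(=N/CCCn1nc(-c2ccccc2)ccc1=O)NC#N`: 93.1 mg/kg
Compound 3, `CC/N=C(/NC#N)NCCCCCn1nc(-c2ccccc2)ccc1=O`: 60.3 mg/kg

These three compounds were tested in a functional assay on the whole organism with Rattus norvegicus as the target; on this read-out higher numbers stand for an effect only at larger amounts of compound and lower numbers for an effect already at smaller amounts. In this assay compound 1 gives 88.5 mg/kg and compound 2 gives 93.1 mg/kg. The two differ in a single place: a group of 8 heavy atoms (4 carbon, 4 nitrogen; no ring) in place of a group of 8 heavy atoms (4 carbon, 4 nitrogen; no ring), on a saturated chain carbon, three bonds along the chain from an aromatic nitrogen. The step that this change made is a 1.1-fold higher number from compound 1 to compound 2 (0.02 log units; within the scatter), so the two values cannot be told apart on this read-out.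

Compound 3 carries the same group as compound 1 but on a longer chain; how its core differs from that of compound 1 is not broken down here. Compound 3 gives 60.3 mg/kg in this assay, and its distances to compound 1 and to compound 2 both lie within the usual scatter, so no order among the three can be claimed.

Compound 4, `CN(C)/C(=N/CCCCCn1nc(-c2ccccc2)ccc1=O)NC#N`, has not yet been measured. It stands to compound 3 as compound 2 stands to compound 1: a group of 8 heavy atoms (4 carbon, 4 nitrogen; no ring) in place of a group of 8 heavy atoms (4 carbon, 4 nitrogen; no ring), on a saturated chain carbon, five bonds along the chain from an aromatic nitrogen. The place differs from the earlier change, which sat three bonds along the chain from an aromatic nitrogen rather than five, so this is the same kind of change rather than the same change. Because the earlier step was a 1.1-fold higher number from compound 1 to compound 2 (0.02 log units; within the scatter), the step from compound 3 to compound 4 is expected to be about as small, a 1.0-fold higher number from compound 3 to compound 4 (0.02 log units; within the scatter). Compound 4 is therefore estimated at 63 mg/kg, with a likely range from 35 mg/kg to 115 mg/kg.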

Compound 4, dose for half-maximal effect: 53.1 mg/kg
For compound 4 the middle estimate is 1.2-fold (0.07 log units) above the measured one; low and high end bracket the measured number.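

In this assay the exchange on the saturated chain carbon, five bonds along the chain from an aromatic nitrogen, replaces the group with 2 hydrogen-bond donors by the group with 1 hydrogen-bond donor and gives a 1.1-fold lower number from compound 3 to compound 4 (0.06 log units; within the scatter), so it cannot be told from no change at all. Set beside the same exchange on the shorter chain, the result looks alike: the same change on two cores in this assay, a 1.1-fold higher number (0.02 log units; within the scatter) from compound 1 to compound 2 and a 1.1-fold lower number (0.06 log units; within the scatter) from compound 3 to compound 4, 1.2-fold (0.08 log units) apart, within the scatter of two such steps. This shows that in these two pairs the exchange leaves no readable mark on the dose needed in the rat, whichever of the two cores carries it, but it does not show that a larger effect would carry over from one core to another, as neither step rises above the scatter, and two pairs make no rule for the wider series.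

The compounds shown leave open whether the same quiet result would hold on a longer chain than that of compound 3, or on a core with other groups added to it. They also leave open what an amine or a carboxylic acid would do in place of the groups exchanged here, and so which change, if any, would move the dose by more than the scatter.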